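A few compounds are considered here, and "the series" means these few. Any claim that something is new, unique, unknown or untested is made for them only; others in the source may bear on it.

Compound 1 has the structure `O=C(Nc1cccc(-n2cc(-c3ccncc3)c(-c3ccc(Cl)c(O)c3)n2)c1)Nc1cc(C(F)(F)F)cc(C(F)(F)F)c1`. In a functional assay on T47D cells (Homo sapiens) for inhibition, read by sulforhodamine B assay, with a stated time of 48 h (on this read-out lower numbers stand for higher toxicity in this test and higher numbers for lower toxicity in this test), compound 1 gives > 50000 nM, which is a limit of the test and not a number. For the measured compounds named here, compound 2, with the structure `COc1cc(-c2nn(-c3cccc(NC(=O)Nc4ccc(Cl)c(C(F)(F)F)c4)c3)cc2-c2ccncc2)ccc1Cl`, is the only other compound measured here. In this assay compound 2 gives > 32500 nM, again a limit rather than a number. Compound 1 thus stands at the limit of > 50000 nM in this assay, at which 1 of the 2 values shown sits. The other value shown stands at the limit of > 32500 nM in this assay, at which 1 of the 2 values shown sits. Going by the values given here, no pair of measured compounds differing in a single place exists, so no measured step can be drawn. Compound 3 is `O=C(Nc1cccc(-n2cc(-c3ccncc3)c(-c3ccc(Cl)c(O)c3)n2)c1)Nc1cccc(C(F)(F)F)c1`. It differs from compound 1 in one respect: hydrogen in place of trifluoromethyl on an aromatic carbon. With both known values sitting at limits, the step expected from compound 1 to compound 3 in this assay is a number no higher from compound 1 to compound 3 (the limit leaves the size open), none beyond the scatter. Compound 3 is accordingly estimated at 50000 nM, within 20000 nM to 120000 nM, and the test is expected most likely to report only a limit once more.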

Compound 3, concentration lethal to 50% of the cells: > 32500 nM
Compound 3: only a limit was reported (the forecaster's own chance of this, stated with the estimate: 80%); the middle value is on the limit's open side.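

In this assay compound 3 gives > 32500 nM, which is a limit and not a number. Compound 1 also stands at a limit, so no step can be read between compound 1 and compound 3. The compounds shown leave open what hydrogen in place of trifluoromethyl does to this read-out.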